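Fluoro in Place of Methyl on the Benzyl Group

The compounds below may be only part of what the source reports. "The series", "measured", "known", "first", "only" and "open" are said of these compounds alone.

Compound 1 `Cc1ccc(CS/C(=C/c2ccc(O)cc2)C(=O)c2ccc(Cl)cc2)cc1` — 10000 nM
Compound 2 `COc1ccccc1/C=C(/SCc1ccc(C)cc1)C(=O)c1ccc(Cl)cc1` — 10000 nM

In a functional assay on DU-145 cells (Homo sapiens) for inhibition, read by trypan blue exclusion, with a stated time of 96 h (a lower number here means a stronger inhibitor of growth, a higher number a weaker inhibitor of growth), compound 1 gives 10000 nM. Compound 2, which carries 2-methoxyphenyl in place of 4-hydroxyphenyl on a double-bonded chain carbon, gives 10000 nM in this assay; the step of no change at the digits printed from compound 1 to compound 2 (within the scatter) shows that this swap leaves the number where it was. Within the data shown here, compound 1 thus stands level with compound 2 on the numbers so far.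

Compound 3 `O=C(/C(=C\c1ccc(O)cc1)SCc1ccc(F)cc1)c1ccc(Cl)cc1` differs from compound 1 by fluoro in place of methyl on an aromatic carbon. Among the measured compounds shown here, no measured step touches the (4-methylbenzyl)sulfanyl part, so nothing measured speaks directly to this change. For the measured compounds named here, the one step that was measured, a swap on the chain carbon, moved nothing beyond the scatter. Compound 3 is therefore expected to stay close to compound 1, with no change at the digits printed from compound 1 to compound 3 (within the scatter) estimated as no change beyond the scatter. Compound 3 is expected to give 10000 nM in this assay, within 4000 nM to 25000 nM.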

Compound 3, concentration for 50% growth inhibition: 25000 nM
Compound 3: the middle estimate sits 2.5-fold (0.40 log units) below what was measured; the measured number falls inside the stated range.
By their numbers in this assay, from the lowest: compounds 1 and 2 (each within the scatter of the next); then compound 3.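

In this assay, fluoro in place of methyl on the benzyl group gives a 2.5-fold higher number from compound 1 to compound 3 (0.40 log units; beyond the scatter), a modest step towards weaker growth inhibition. This shows that the group at this place on the benzyl ring can move the number, whereas the swap on the chain carbon gave no change at the digits printed from compound 1 to compound 2 (within the scatter). Nothing available explains why this change raises the number.

On these data alone, with only methyl and fluoro compared here, it remains open whether trifluoromethyl, an amine or a carboxylic acid at this place would lower the number or raise it further. As far as these compounds go, it is also open whether the same swap would give a similar step on a compound carrying the 2-methoxyphenyl group of compound 2 in place of 4-hydroxyphenyl.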